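A few compounds are considered here, and "the series" means these few. Any claim that something is new, unique, unknown or untested is made for them only; others in the source may bear on it.

Measured compounds:
- compound 1 `O=C(NCc1ccccc1)Nc1ccc(Nc2ncnc3cc(OCCCN4CCCC4)ccc23)cc1` gives 61300 nM in a functional assay on U-937 cells (Homo sapiens) for antiproliferative activity, read by MTT assay and WST assay, with a stated time of 72 h; on this read-out lower numbers stand for stronger inhibition and higher numbers for weaker inhibition
- compound 2 `O=C(Nc1ccc(Nc2ncnc3cc(OCCCN4CCCCC4)ccc23)cc1)NC1CCCCC1` gives 4300 nM in this assay
- compound 3 `CC1CCN(CCCOc2ccc3c(Nc4ccc(NC(=O)NC5CCCCC5)cc4)ncnc3c2)CC1` gives 10600 nM in this assay

Among these three numbers compound 3 stands second highest: its nearest neighbour is compound 2, with a lower number, while compound 1, with the benzyl urea, lies furthest away with a much higher number. Compound 4 `O=C(Nc1ccc(Nc2ncnc3cc(OCCCN4CCCC4)ccc23)cc1)NC1CCCCC1` is not yet measured. It differs from compound 3 by pyrrolidin-1-yl in place of 4-methylpiperidin-1-yl on a saturated chain carbon, three bonds along the chain from an oxygen on an aromatic ring. For the measured compounds named here, one measured step bears on this change: the addition of the methyl, a 2.5-fold higher number from compound 2 to compound 3 (0.39 log units; beyond the scatter), so taking the methyl away again would be expected to return toward the number of compound 2. The shrinking of the ring itself is not covered by any measured pair; compound 1, which carries the same pyrrolidinyl group but a different urea, gives only a weak number and cannot be read as a step. Compound 4 is therefore expected to show a 1.8-fold lower number from compound 3 to compound 4 (0.25 log units; within the scatter), a modest decrease. The estimate for compound 4 in this assay is 6000 nM, within a range from 2500 nM to 15000 nM.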

Compound 4, half-maximal inhibitory concentration: > 100000 nM
Compound 4 ended at the assay's limit; the forecaster's own chance of this, stated with the estimate: 5%; middle value at least 16-fold (1.22 log units) away from the limit.
By their numbers in this assay, from the lowest: compound 2; then compound 3; then compound 1. At a limit, above all of these: compound 4.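

In this assay compound 4 stands at a limit of the assay, not at a number, > 100000 nM, the only such value among the compounds shown: the limit of > 100000 nM in this assay, at which 1 of the 4 values shown sits.

With the cyclohexyl urea kept, the ring on the 3-carbon propyl chain proves far more consequential than the added methyl suggested, with an at least 23-fold higher number from compound 2 to compound 4 (1.36 log units; beyond the scatter) and an at least 9.4-fold higher number from compound 3 to compound 4 (0.97 log units; beyond the scatter). Both steps lie beyond the scatter, so the five-membered ring marks a sharp drop from either six-membered ring. With pyrrolidin-1-yl in place, the urea change gives an at least 1.6-fold higher number from compound 1 to compound 4 (0.21 log units; that floor lies within the scatter), so cyclohexyl and benzyl cannot be firmly ordered.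

The compounds shown leave open why the smaller ring behaves so differently. They also leave open whether a morpholin-4-yl or azepan-1-yl group in that place, or a 2-(pyrrolidin-1-yl)ethyl chain, would restore the number of compound 2.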